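Amide aryl variation on the shared core

A few compounds are considered here, and "the series" means these few. Any claim that something is new, unique, unknown or untested is made for them only; others in the source may bear on it.

Working notes on the series. Within the data shown here, compound 1 `O=C(Nc1cccc(-c2oc3cc(-c4ccc(F)cc4)ccc3c(=O)c2O)c1)c1ccc(F)cc1` gives 9280 nM in a functional assay on HepG2 cells (Homo sapiens) for antiproliferative activity, read by CCK-8 assay, with a stated time of 72 h (a higher number here means a weaker inhibitor, a lower number a stronger inhibitor), and stands as the higher of the two numbers measured so far. Compound 2 `Cc1ccc(C(=O)Nc2cccc(-c3oc4cc(-c5ccc(F)cc5)ccc4c(=O)c3O)c2)cc1` gives 2320 nM in this assay. Among the measured compounds shown here, the single step between measured compounds, a 4.0-fold lower number from compound 1 to compound 2 (0.60 log units; beyond the scatter), alters the ring attached to the carbonyl carbon and is the only guide to what changes at that place do here.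

Compound 3 `O=C(Nc1cccc(-c2oc3cc(-c4ccc(F)cc4)ccc3c(=O)c2O)c1)c1cnc(Cl)nc1Cl` differs from compound 1 by 2,4-dichloropyrimidin-5-yl in place of 4-fluorophenyl on a carbonyl carbon. The step from compound 1 to compound 2 bears on this, as it too changes the group on the carbonyl carbon, but it exchanges one substituent on the ring, whereas here the whole ring is replaced, so the size of the effect cannot be read off directly. A step of modest size, with a lower number somewhat more likely than a higher one, is expected in this assay, with wide uncertainty. Compound 3 is therefore estimated at 5000 nM, within 1500 nM to 16000 nM, meaning an expected 1.9-fold lower number from compound 1 to compound 3 (0.27 log units; within the scatter).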

Compound 3, half-maximal inhibitory concentration: > 100000 nM
Compound 3 ended at the assay's limit (the forecaster's own chance of this, stated with the estimate: 5%); middle value at least 20-fold (1.30 log units) from the limit.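

Compound 3 gives no number, only a limit of this assay: the limit of > 100000 nM in this assay, at which 1 of the 3 values shown sits. At this place, on a carbonyl carbon whose other neighbour is the amide-type nitrogen, the earlier pair showed only a modest shift, a 4.0-fold lower number from compound 1 to compound 2 (0.60 log units; beyond the scatter), while the whole-ring exchange gives an at least 10-fold higher number from compound 1 to compound 3 (1.03 log units; beyond the scatter) and an at least 43-fold higher number from compound 2 to compound 3 (1.63 log units; beyond the scatter). The group on this carbonyl carbon can therefore do far more than tune the read-out: with 2,4-dichloropyrimidin-5-yl in place of either 4-fluorophenyl or 4-methylphenyl, the compound leaves the measurable range of this assay, and the data give no cause for this.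

The exchange brings in the ring nitrogens and the chlorines together, so the compounds shown cannot separate their contributions; a dichlorophenyl ring and an unsubstituted pyrimidine ring on the same carbonyl carbon would bear directly on that. Also open, going by these compounds, is whether the gain seen with methyl over fluoro extends to other groups on the phenyl ring, such as methoxy, an amine or a longer alkyl chain.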